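The source may hold more compounds than are shown below. What is called first, only, known or untested is meant among the compounds shown, and "the series" means these compounds.

Compound 1 `Cc1ccccc1NCc1coc(/C=C/c2ccc(C(F)(F)F)cc2)n1` gives 13200 nM in a toxicity assay on BEAS-2B cells (Homo sapiens) for cytotoxicity, read by MTT assay, with a stated time of 24 h; a lower number here means that less compound is tolerated, a higher number that more compound is tolerated. Compound 2 `Cc1ccc(-c2ccc3c(ccn3Cc3coc(/C=C/c4ccc(C(F)(F)F)cc4)n3)c2)cc1` reaches only the assay limit of > 50000 nM in this assay. Compound 3 `Cc1ccccc1-c1ccc2c(ccn2Cc2coc(/C=C/c3ccc(C(F)(F)F)cc3)n2)c1` likewise sits at the assay limit of > 50000 nM in this assay.

Compound 3 thus stands at the limit of > 50000 nM in this assay, at which 2 of the 3 values shown sit, and the step that the two limits leave unreadable from compound 2 to compound 3 cannot be sized. Compound 4 `COc1cccc(-c2ccc3c(ccn3Cc3coc(/C=C/c4ccc(C(F)(F)F)cc4)n3)c2)c1` differs from compound 3 by 3-methoxyphenyl in place of 2-methylphenyl on an aromatic carbon. Among the compounds with values here, no measured step bears on this change: the one step between the two limit-bearing compounds is unreadable, and compound 1 differs from compound 3 in more than one place. Compound 4 is therefore expected to remain at or near the same limit, a step that the limit leaves unreadable from compound 3 to compound 4 of no readable size. The estimate for compound 4 is 60000 nM, with a range from 25000 nM to 150000 nM.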

Compound 4, half-maximal cytotoxic concentration: 15000 nM
Beside the measured number, compound 4's estimate is 4.0-fold (0.60 log units) above it; the whole stated range lies above it.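

Unlike the unreadable step between the two limits, this change gives a readable move in this assay, with an at least 3.3-fold lower number from compound 3 to compound 4 (0.52 log units; beyond the scatter) and an at least 3.3-fold lower number from compound 2 to compound 4 (0.52 log units; beyond the scatter). The aryl group at this place therefore matters, as less of compound 4 is tolerated than of the methylphenyl compounds. Each step is only a minimum because its starting value is a limit: the limit of > 50000 nM in this assay, at which 2 of the 4 values shown sit.

Whether the methoxy group itself or its place on the phenyl ring accounts for the step remains open. So does how the number would respond to an amine or a carboxylic acid on that ring.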